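Diaryl ureas on a quinoline ether core: chloro for trifluoromethyl

This account rests on a few compounds, and the source may have more. Where it says the series, first, only, none or still open, it means among the compounds named here.

Measured so far:
compound 1, `COc1cc2cc(Oc3ccc(NC(=O)Nc4ccccc4)cc3)c(C)nc2cc1OC`, gives 84.5% in a functional assay on ACHN cells (Homo sapiens) for inhibition, read by sulforhodamine B assay, with a stated time of 48 h, tested at 10 uM; a lower number here means a stronger effect, a higher number a weaker effect of the compound at the concentration tested;
compound 2, `COc1cc2cc(Oc3ccc(NC(=O)Nc4cccc(C(F)(F)F)c4)cc3)c(C)nc2cc1OC`, gives 11.2% in this assay;
compound 3, `COc1cc2cc(Oc3ccc(NC(=O)Nc4ccc(Cl)c(C(F)(F)F)c4)cc3)c(C)nc2cc1OC`, gives 13.6% in this assay.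

Compound 3 stands second highest of the three numbers. Its nearest neighbour is compound 2, with a number 2.4 percentage points higher from compound 2 to compound 3 (within the scatter); its furthest is compound 1, with a number 70.9 percentage points lower from compound 1 to compound 3 (beyond the scatter).

Compound 4 is `COc1cc2cc(Oc3ccc(NC(=O)Nc4ccc(Cl)c(Cl)c4)cc3)c(C)nc2cc1OC`, not yet measured. Against compound 3 the change is chloro in place of trifluoromethyl on an aromatic carbon, that is, 4-chloro-3-(trifluoromethyl)phenyl becomes 3,4-dichlorophenyl.

Among the measured compounds shown here, two measured steps bear on it. The trifluoromethyl itself carries the whole effect seen so far: a number 73.3 percentage points lower from compound 1 to compound 2 (beyond the scatter). The chloro that compound 4 keeps adds nothing measurable on its own: a number 2.4 percentage points higher from compound 2 to compound 3 (within the scatter). For the measured compounds named here, no measured step swaps chloro for trifluoromethyl, so whether a chloro at that position holds the low number of compound 3 is open. A modest rise beyond the scatter is expected, well short of compound 1, with a number 11.4 percentage points higher from compound 3 to compound 4 (beyond the scatter) as the expected step in this assay. Compound 4 is therefore estimated at 25%, in the range 8% to 55%.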

Compound 4, a percentage reported as activity, at one concentration (the size of the read-out at that concentration, not a potency): 16.4%
For compound 4 the middle estimate is 8.6 percentage points above the measured one, and the stated range covers the measured number.
By their numbers in this assay, from the lowest: compounds 2, 3 and 4 (each within the scatter of the next); then compound 1.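

In this assay, trifluoromethyl on this aromatic carbon, ortho to a chloro group, can give way to chloro with no readable shift (a number 2.8 percentage points higher from compound 3 to compound 4 (within the scatter)), so within this pair the low number does not require trifluoromethyl. Among the compounds shown here, the 3,4-dichlorophenyl group also reads level with 3-(trifluoromethyl)phenyl (a number 5.2 percentage points higher from compound 2 to compound 4 (within the scatter)) and keeps the large gap from the plain phenyl group (a number 68.1 percentage points lower from compound 1 to compound 4 (beyond the scatter)), so the effect on the distal ring, first seen only with trifluoromethyl-bearing compounds, now also appears in a compound with no trifluoromethyl at all. Nothing among the data shown accounts for chloro and trifluoromethyl reading alike at this place.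

Compound 4 carries two chloro groups, so the compounds shown do not tell whether a single chloro at this place, without the second one, would hold the low number, nor how a methyl, a methoxy, a nitrile, an amine or a carboxylic acid would read there. Going by these compounds, with one read-out at one concentration, compound 2, compound 3 and compound 4 also stay unseparated, and any ranking among them remains open.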